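The source may report more compounds than this note shows. Statements on the series, on what has been measured and on what is new or still open speak of the compounds shown alone.

Of the compounds shown here, two sharing one core have been measured. Compound 1 `C=CC1=C(C(=O)NCc2ccc(C)cc2)C(c2ccc(OC)cc2)OC1` gives 43100 nM in a functional assay on QGY7701 cells (Homo sapiens) for cytotoxicity, read by MTT assay, with a stated time of 24 h; on this read-out higher numbers stand for weaker inhibition and lower numbers for stronger inhibition. Compound 2 `C=CC1=C(C(=O)NCc2ccc(C)cc2)C(c2ccc(F)cc2)OC1` differs only by fluoro in place of methoxy on an aromatic carbon, and in this assay compound 2 gives 62100 nM. That single change made a 1.4-fold higher number from compound 1 to compound 2 (0.16 log units; within the scatter), so the two numbers cannot be told apart with confidence. Compound 2 therefore has the higher of the two numbers, but only by a margin that repeated measurements would blur.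

Compound 3 `C=CC1=C(C(=O)NC2CCCCC2)C(c2ccc(F)cc2)OC1` has not yet been measured. It keeps the fluoro-bearing ring of compound 2 and changes a different part: cyclohexyl in place of 4-methylbenzyl on an amide-type nitrogen. Among the measured compounds shown here, no measured step touches the group on the amide-type nitrogen; the only step known concerns the aromatic ring, and it stayed within the scatter. There is thus nothing in these data to point to a direction, and the step from compound 2 to compound 3 is expected to be small, a 1.0-fold higher number from compound 2 to compound 3 (0.02 log units; within the scatter). On that basis compound 3 is expected to give about 65000 nM in this assay, with a range from 20000 nM to 200000 nM.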

Compound 3, half-maximal inhibitory concentration: 40500 nM
For compound 3 the middle estimate is 1.6-fold (0.21 log units) above the measured one, within the range that was stated.
By their numbers in this assay, from the lowest: compounds 3, 1 and 2 (each within the scatter of the next).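

In this assay, among the compounds shown here, the first look at the group on the amide-type nitrogen gives a 1.5-fold lower number from compound 2 to compound 3 (0.19 log units; within the scatter), with cyclohexyl in place of 4-methylbenzyl. This swaps a six-membered aromatic ring of carbon only for a six-membered non-aromatic ring of carbon only, and compound 3 still cannot be told apart from compound 2, so among these compounds, an aromatic ring in this group is not needed for a number of this size. No supporting measurement bears on why the two groups read alike.

Going by these compounds, it remains open whether a group on the amide-type nitrogen that carries an amine or a carboxylic acid, or a short chain such as ethyl, would move the number beyond the usual scatter. It is also open whether the two places act independently, since among the compounds shown the methoxy-bearing ring appears only with 4-methylbenzyl and cyclohexyl appears only with the fluoro-bearing ring.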